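The source may report more compounds than this note shows. Statements on the series, on what has been measured and on what is new or still open speak of the compounds shown alone.

Compound 1 `CCCCCCCCNC(=O)[C@@H](NC(=O)c1nccc2ccccc12)[C@@H](C)O` gives 88200 nM in a functional assay on HepG2 cells (Homo sapiens) for cytotoxicity, read by MTT assay, with a stated time of 48 h; a higher number here means a weaker inhibitor, a lower number a stronger inhibitor. Among the numbers on record it is the lowest of two, though the nearest neighbour, compound 2 `C/C=C/C=C/C(=O)N[C@H](C(=O)NCCCCCCCC)[C@@H](C)O` with 102000 nM, sits within the scatter of it, so no order between these two can be claimed. Compound 3 `C/C=C/C=C/C(=O)N[C@H](C(=O)NCCCCCCCCCCCC)[C@@H](C)O` reaches only the limit of this assay, > 400000 nM, and no number. Within the data shown here, the one step that bears on a chain lengthening is an at least 3.9-fold higher number from compound 2 to compound 3 (0.59 log units; beyond the scatter), which is at least modest and runs toward the weaker side; the line the limit of > 400000 nM in this assay, at which 1 of the 3 values shown sits, shows that the longer chain of compound 3 ends in the limit.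

Compound 4 `CCCCCCCCCCCCCCNC(=O)[C@@H](NC(=O)c1nccc2ccccc12)[C@@H](C)O` differs from compound 1 by hexyl in place of hydrogen on a saturated chain carbon, eight bonds along the chain from an amide-type nitrogen, the same kind of change as from compound 2 to compound 3 but longer by two carbons. From that step the expectation for compound 4 is a higher number in this assay, with a fair chance that it too is reported only as a limit. The estimate for compound 4 is 400000 nM, in the range 150000 nM to 1500000 nM, which means an expected step of a 4.5-fold higher number from compound 1 to compound 4 (0.66 log units; beyond the scatter).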

Compound 4, half-maximal inhibitory concentration: 28600 nM
Compound 4: the middle estimate sits 14-fold (1.15 log units) above what was measured; measured number below the stated range.
By their numbers in this assay, from the lowest: compound 4; then compounds 1 and 2 (each within the scatter of the next). At a limit, above all of these: compound 3.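

Hexyl in place of hydrogen on a saturated chain carbon, eight bonds along the chain from an amide-type nitrogen, lowers the number in this assay: a 3.1-fold lower number from compound 1 to compound 4 (0.49 log units; beyond the scatter). Lengthening the chain at this place therefore has no single direction across the series, while an at least 3.9-fold higher number from compound 2 to compound 3 (0.59 log units; beyond the scatter) runs the other way. Compound 3 remains a limit and not a number: the limit of > 400000 nM in this assay, at which 1 of the 4 values shown sits.

The two steps differ both in the added chain, hexyl against butyl, and in the acyl part of the amide that carries the hydroxyl-bearing core, so the compounds shown cannot separate these two differences. Also open, on these data alone, is how the number in this assay responds to a still longer chain, or to an amine or a carboxylic acid, at this place.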